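Working notes: aryl swap at the shared core, cytotoxicity

The source may report more compounds than this note shows. Statements on the series, on what has been measured and on what is new or still open speak of the compounds shown alone.

Compound 3 `COc1nc(-c2ccc(OC(F)(F)F)cc2)ccc1[C@@H](c1ccccc1)[C@@](O)(CCN(C)C)c1cccc2ccccc12` is the reference point for the next step. In a toxicity assay on Vero cells (Chlorocebus sabaeus) for cytotoxicity (a lower number here means that less compound is tolerated, a higher number that more compound is tolerated), compound 3 gives > 50 ug/mL, which is a limit of the assay and not a number. Compound 1 `COc1nc(-c2cccc(Cl)c2)ccc1[C@@H](c1ccccc1)[C@@](O)(CCN(C)C)c1cccc2ccccc12` in this assay gives > 50 ug/mL, again a limit. Compound 2 `COc1ccc(-c2ccc([C@@H](c3ccccc3)[C@@](O)(CCN(C)C)c3cccc4ccccc34)c(OC)n2)cc1` gives > 50 ug/mL, also a limit. The three values together mark (the limit of > 50 ug/mL in this assay, at which 3 of the 3 values shown sit). The change to compound 4 `COc1nc(-c2cnsc2)ccc1[C@@H](c1ccccc1)[C@@](O)(CCN(C)C)c1cccc2ccccc12` is 1,2-thiazol-4-yl in place of 4-(trifluoromethoxy)phenyl on an aromatic carbon. Going by the values given here, the steps that bear on it are a step that the two limits leave unreadable from compound 1 to compound 2, a step that the two limits leave unreadable from compound 1 to compound 3 and a step that the two limits leave unreadable from compound 2 to compound 3; none has a readable size, so no step beyond the scatter in this assay can be foreseen in either direction. For compound 4 the estimate in this assay is 50 ug/mL, within 30 ug/mL to 100 ug/mL, corresponding to an expected step of a number no higher from compound 3 to compound 4 (the limit leaves the size open).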

Compound 4, half-maximal cytotoxic concentration: 26.3 ug/mL
For compound 4 the middle estimate is 1.9-fold (0.28 log units) above the measured one, and the stated range ends above it.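

In this assay, going by these compounds alone, compound 4 gives 26.3 ug/mL, the only number at this position that is not a limit, with 1,2-thiazol-4-yl in place of the substituted phenyl groups. The steps are an at least 1.9-fold lower number from compound 3 to compound 4 (0.27 log units; that floor lies within the scatter), an at least 1.9-fold lower number from compound 2 to compound 4 (0.27 log units; that floor lies within the scatter) and an at least 1.9-fold lower number from compound 1 to compound 4 (0.27 log units; that floor lies within the scatter), so these floors alone establish no change beyond the scatter. The other three compounds remain limits: the limit of > 50 ug/mL in this assay, at which 3 of the 4 values shown sit.

The steps among compound 1, compound 2 and compound 3 cannot be read. As far as these compounds go, how an amine or a carboxylic acid at this position would read in this assay stays open.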